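Adding a nitro group to compound 3

This account rests on a few compounds, and the source may have more. Where it says the series, first, only, none or still open, it means among the compounds named here.

Among the measured compounds shown here, in a functional assay on U-87MG ATCC cells (Homo sapiens) for cytotoxicity, read by MTT assay, with a stated time of 48 h (on this read-out lower numbers stand for stronger inhibition and higher numbers for weaker inhibition), compound 3 `C/C(=N\NC(=S)Nc1ccccc1)c1ccccn1` gives 1.4 nM, the lowest of the three numbers so far. Compound 4 `C/C(=N\NC(=S)Nc1cccc([N+](=O)[O-])c1)c1ccccn1` comes from it by one change, nitro in place of hydrogen on an aromatic carbon. Two relatives already carry that nitro: compound 1 `CC(=NNC(=S)Nc1cccc([N+](=O)[O-])c1)c1ccccn1` gives 69 nM and compound 2 `C/C(=N/NC(=S)Nc1cccc([N+](=O)[O-])c1)c1ccccn1` gives 69 nM. For the measured compounds named here, the one measured step, no change at the digits printed from compound 1 to compound 2 (within the scatter), concerns only how a double bond is drawn (the fact that one of compounds 1 and 2 is drawn with a defined configuration and the other without, at the place where they differ), so it says little against using both as guides. With compound 2 at 69 nM as the guide, a clear rise beyond the scatter is expected in this assay. The expected change is a 43-fold higher number from compound 3 to compound 4 (1.63 log units; beyond the scatter). For compound 4 the estimate is 60 nM, with a range of 10 nM to 200 nM.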

Compound 4, half-maximal inhibitory concentration: 69 nM
Beside the measured number, compound 4's estimate is 1.2-fold (0.06 log units) below it, and the stated range covers the measured number.
By their numbers in this assay, from the lowest: compound 3; then compounds 1, 2 and 4 (each within the scatter of the next).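

Among the compounds shown here, with the drawn configuration now the same on both sides, nitro meta to a large group is the only change behind a 49-fold higher number from compound 3 to compound 4 (1.69 log units; beyond the scatter) in this assay. This gives a direct one-change measure of what replacing that hydrogen does in the nitro series. Among the nitro compounds, the way the double bond is drawn makes no visible difference, with no change at the digits printed from compound 2 to compound 4 (within the scatter) and no change at the digits printed from compound 1 to compound 4 (within the scatter).

As far as these compounds go, whether the rise is specific to nitro remains open, since an amine or a carboxylic acid at this place could behave differently. From the compounds shown here alone, the effect of nitro elsewhere on the ring also remains open.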